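A few compounds are considered here, and "the series" means these few. Any claim that something is new, unique, unknown or untested is made for them only; others in the source may bear on it.

Compound 1, `Cn1cnc2c1c(=O)n(CC(=O)OC(C)(C)C)c(=O)n2C`, gives 17.2% in a functional assay on MGC-803 cells (Homo sapiens) for inhibition, read by MTT assay, with a stated time of 48 h, tested at 20 uM; a lower number here means less inhibition, a higher number more inhibition at the concentration tested (going by the name of the read-out). Compound 2, `Cn1cnc2c1c(=O)n(CC(=O)N1CCOCC1)c(=O)n2C`, gives 19.9%. Compound 3, `Cn1cnc2c1c(=O)n(CC(=O)N1CCSCC1)c(=O)n2C`, gives 5.6%.

Compound 3 stands lowest of these three numbers. Its nearest neighbour is compound 1, reached by a number 11.6 percentage points lower from compound 1 to compound 3 (beyond the scatter), and its furthest is compound 2, reached by a number 14.3 percentage points lower from compound 2 to compound 3 (beyond the scatter); both of these steps lie beyond the scatter, whereas compound 1 and compound 2 differ only by a number 2.7 percentage points higher from compound 1 to compound 2 (within the scatter), which is within it.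

Compound 4, `CN1CCN(C(=O)Cn2c(=O)c3c(ncn3C)n(C)c2=O)CC1`, differs from compound 3 in one place: 4-methylpiperazin-1-yl in place of thiomorpholin-4-yl on a carbonyl carbon. For the measured compounds named here, no measured step covers the 4-methylpiperazin-1-yl group itself. Going by the values given here, the steps that bear on the change are those into compound 3, a number 14.3 percentage points lower from compound 2 to compound 3 (beyond the scatter) and a number 11.6 percentage points lower from compound 1 to compound 3 (beyond the scatter), both modest drops when the thiomorpholin-4-yl group arrived. With that group leaving and another six-membered ring with two hetero atoms entering, a return toward the level of compound 1 and compound 2 is expected, though with little support from a single new ring. Compound 4 is therefore expected to move by a number 9.4 percentage points higher from compound 3 to compound 4 (within the scatter), upward and of modest size. Compound 4 is estimated at 15%, within a range from 3% to 30%.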

Compound 4, a percentage reported as inhibition, at one concentration (the size of the read-out at that concentration, not a potency): 8.6%
For compound 4 the middle estimate is 6.4 percentage points above the measured one, within the range that was stated.
By their numbers in this assay, from the lowest: compounds 3, 4, 1 and 2 (each within the scatter of the next, the first and the last beyond it).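

In this assay, exchanging the thiomorpholin-4-yl group for 4-methylpiperazin-1-yl on the carbonyl carbon gives a number 3 percentage points higher from compound 3 to compound 4 (within the scatter), so these two rings are not told apart at this position. Measured against the morpholin-4-yl group, the same 4-methylpiperazin-1-yl group gives a number 11.3 percentage points lower from compound 2 to compound 4 (beyond the scatter), a step beyond the scatter, which makes morpholin-4-yl the only one of the three six-membered rings shown whose number stands clear of the other two, while the step against tert-butoxy, a number 8.6 percentage points lower from compound 1 to compound 4 (within the scatter), stays within the scatter, so compound 1 goes against any clean split between the groups. No measurement shown here accounts for these differences.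

The compounds shown leave open whether an open-chain amine such as diethylamino, an aniline or a free carboxylic acid on the same carbonyl carbon would give a number that stands clear of those of compound 1 and compound 2. They also leave open whether a longer chain between the shared core and the carbonyl carbon would change the order of these groups.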